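Cytotoxicity of aryl ketone acetamides on DLA cells

The source may hold more compounds than are shown below. What is called first, only, known or untested is meant among the compounds shown, and "the series" means these compounds.

Measured so far:
compound 1 `Cc1ccc(C(=O)c2ccc(OCC(=O)Nc3nc(-c4ccccc4)cs3)c(C)c2)cc1` — 26400 nM
compound 2 `COc1ccc(-c2csc(NC(=O)COc3ccc(C(=O)c4ccc(C)cc4)cc3C)n2)cc1` — 17200 nM
compound 3 `Cc1cc(C(=O)c2ccc(F)cc2)ccc1OCC(=O)Nc1nc(-c2ccccc2)cs1` — 33300 nM

In a functional assay on DLA cells (Mus musculus) for cytotoxicity, read by MTT assay, with a stated time of 48 h (on this read-out lower numbers stand for stronger inhibition and higher numbers for weaker inhibition), compound 2 gives 17200 nM, the lowest of the three numbers; the other two lie within the scatter of it, so no order among them can be read. The step of a 1.5-fold lower number from compound 1 to compound 2 (0.19 log units; within the scatter) adds a methoxy to the aryl group on the shared core of compound 1, and the step of a 1.3-fold higher number from compound 1 to compound 3 (0.10 log units; within the scatter) exchanges fluoro for methyl on the aryl ring of the ketone; neither moves the read-out beyond the scatter.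

Compound 4 `COc1ccc(-c2csc(NC(=O)COc3ccc(C(=O)c4cccc(Br)c4)cc3C)n2)cc1` is not yet measured. It differs from compound 2 by 3-bromophenyl in place of 4-methylphenyl on a carbonyl carbon. For the measured compounds named here, the only measured step on the same ring, a 1.3-fold higher number from compound 1 to compound 3 (0.10 log units; within the scatter), stayed within the scatter, but no measured pair tests bromine or this ring position of the entering group, so the guidance is thin. The expectation is a step of a 1.0-fold lower number from compound 2 to compound 4 (0.01 log units; within the scatter) in this assay, that is, none beyond the scatter. Compound 4 is therefore estimated at 17000 nM, within 7000 nM to 40000 nM.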

Compound 4, half-maximal inhibitory concentration: 36600 nM
Compound 4: middle estimate off by 2.2-fold (0.33 log units), on the low side, within the range that was stated.
By their numbers in this assay, from the lowest: compounds 2, 1, 3 and 4 (each within the scatter of the next, the first and the last beyond it).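

For the compounds shown here, the exchange of 4-methylphenyl for 3-bromophenyl on a carbonyl carbon gives a 2.1-fold higher number from compound 2 to compound 4 (0.33 log units; beyond the scatter) in this assay, the first single change here to pass the scatter and one towards weaker inhibition, whereas fluoro in place of methyl on that same ring gave only a 1.3-fold higher number from compound 1 to compound 3 (0.10 log units; within the scatter) on the core of compound 1. The group on the carbonyl carbon is therefore a place where the read-out can move, though only modestly so far, and the counts of heavy atoms, donors and acceptors are the same for the leaving and entering groups, so those counts do not separate them. Nothing available accounts for the step, and this single exchange alters the halogen and the ring position together.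

On these data alone, it remains open whether bromine or the ring position carries the step, and whether the same exchange would act alike on the core of compound 1, which lacks the methoxy. Also open, as far as these compounds go, is how a plain phenyl, or a phenyl bearing an amine or a carboxylic acid, would read at this carbonyl carbon.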